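Triazine diamines in rat: replacing the sulfanyl group

The source may report more compounds than this note shows. Statements on the series, on what has been measured and on what is new or still open speak of the compounds shown alone.

Compound 1 `CS(=O)(=O)c1cccc(-c2nc(N)nc(N)n2)c1`: -6%
Compound 2 `Nc1nc(N)nc(-c2cccc(F)c2)n1`: 70%
Compound 3 `Nc1nc(N)nc(-c2cccc(SC(F)(F)F)c2)n1`: 87%

In a functional assay on the whole organism with Rattus norvegicus as the target, at a dose of 20 mg/kg by the intraperitoneal route (a higher number here means more inhibition at the dose given (going by the name of the read-out), a lower number less inhibition), compound 3 gives the highest of the three numbers; compound 2 sits below it by a number 17 percentage points higher from compound 2 to compound 3 (beyond the scatter) and compound 1 far below it by a number 93 percentage points higher from compound 1 to compound 3 (beyond the scatter). Compound 4 `Nc1nc(N)nc(-c2cccc([N+](=O)[O-])c2)n1` differs from compound 3 by nitro in place of (trifluoromethyl)sulfanyl on an aromatic carbon. Among the compounds with values here, no measured step places a nitro group on this ring, so the two steps that end at compound 3 are the only guide: a large one, a number 93 percentage points higher from compound 1 to compound 3 (beyond the scatter), and a modest one, a number 17 percentage points higher from compound 2 to compound 3 (beyond the scatter). Both show the entering group here mattering strongly, in the direction of less inhibition when it leaves. For compound 4 a decrease is therefore expected, of about a number 52 percentage points lower from compound 3 to compound 4 (beyond the scatter), with wide uncertainty. Compound 4 is estimated at 35%, between -5% and 75%.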

Compound 4, a percentage reported as inhibition, in the whole organism at one dose (the size of the read-out at that dose, not a potency) in the Rattus norvegicus assay: 85%
Compound 4: middle estimate off by 50 percentage points, on the low side, outside the stated range (above it).
By their numbers in the Rattus norvegicus assay, from the lowest: compound 1; then compound 2; then compounds 4 and 3 (each within the scatter of the next).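

In the Rattus norvegicus assay, nitro in place of (trifluoromethyl)sulfanyl leaves the inhibition unchanged, a number 2 percentage points lower from compound 3 to compound 4 (within the scatter), while nitro stands clear of fluoro, a number 15 percentage points higher from compound 2 to compound 4 (beyond the scatter), and of methylsulfonyl, a number 91 percentage points higher from compound 1 to compound 4 (beyond the scatter). In a physicochemical assay for lipophilicity (a lower number here means a more polar compound, a higher number a more lipophilic compound), compound 3 gives 3.2 and compound 4 gives 1.57, so across this pair the inhibition held while the partition coefficient fell. Among the four groups shown on this aromatic carbon, only methylsulfonyl goes with a loss of inhibition.

The compounds shown leave open whether an amine or a carboxylic acid at this carbon would keep the inhibition.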